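Replacing dipropylamino with diallylamino on the shared core

A few compounds are considered here, and "the series" means these few. Any claim that something is new, unique, unknown or untested is made for them only; others in the source may bear on it.

In a functional assay on SMMC-7221 cells (Homo sapiens) for antiproliferative activity, read by MTT assay, with a stated time of 48 h (on this read-out lower numbers stand for stronger inhibition and higher numbers for weaker inhibition), compound 1 `CCNC(=O)Nc1nc(-c2ccc(OCC)cc2)c(-c2cc(OC)c(OC)c(OC)c2)s1` gives 10.6 nM. Compound 2 `CCOc1ccc(-c2nc(NS(=O)(=O)c3ccc(C)c(C)c3)sc2-c2cc(OC)c(OC)c(OC)c2)cc1` is reported only as a limit, > 5000 nM. Compound 3 `CCCN(CCC)c1nc(-c2ccc(OCC)cc2)c(-c2cc(OC)c(OC)c(OC)c2)s1` is also reported only as a limit, > 5000 nM. Compound 4 `C=CCN(CC=C)c1nc(-c2ccc(OCC)cc2)c(-c2cc(OC)c(OC)c(OC)c2)s1` carries diallylamino in place of dipropylamino on an aromatic carbon. From the compounds shown here alone, two large measured steps bear on this change, an at least 470-fold higher number from compound 1 to compound 2 (2.67 log units; beyond the scatter) and an at least 470-fold higher number from compound 1 to compound 3 (2.67 log units; beyond the scatter), while a step that the two limits leave unreadable from compound 2 to compound 3 remains open. Going by the values given here, compound 4 also lacks the (ethylcarbamoyl)amino group, and no measured step exchanges one dialkylamino-type group for another. The expected change in this assay is therefore none beyond the scatter, a step that the limit leaves unreadable from compound 3 to compound 4. For compound 4, the estimated value is 7000 nM, with an expected range from 2000 nM to 20000 nM.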

Compound 4, half-maximal inhibitory concentration: > 5000 nM
Compound 4 gave a limit, no number; the forecaster's own chance of this, stated with the estimate: 80%; the middle value is on the limit's open side.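

In this assay compound 4 is reported only as a limit, > 5000 nM, so a second dialkylamino-type group, here with 2 double bonds outside aromatic rings, also gives no number at this position. Set against the (ethylcarbamoyl)amino group, diallylamino gives an at least 470-fold higher number from compound 1 to compound 4 (2.67 log units; beyond the scatter). The steps to compound 4 from compound 2 and compound 3 cannot be read: the limit of > 5000 nM in this assay, at which 3 of the 4 values shown sit.

From the compounds shown here alone, whether a free amino group or ethylamino on this aromatic carbon would bring the value back towards that of compound 1, 10.6 nM, stays open. So does any ranking of compound 2, compound 3 and compound 4.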